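The source may report more compounds than this note shows. Statements on the series, on what has been measured and on what is new or still open speak of the compounds shown alone.

Compound 3 `CC1=NC(C)=C(C(=O)O)C(c2cccc(Cl)c2)/C1=C(\O)OC/C=C/C1CCCCC1` gives 3.7 nM in a functional assay on thoracic aorta for inhibition of Voltage-gated L-type calcium channel (Rattus norvegicus) (a lower number here means a stronger inhibitor, a higher number a weaker inhibitor), the lowest of the three numbers shown; compound 2 `CC1=NC(C)=C(C(=O)O)C(c2ccoc2)/C1=C(\O)OC/C=C/c1ccccc1` gives 130 nM and compound 1 `CC1=NC(C)=C(C(=O)O)C(c2cccnc2)/C1=C(\O)OC/C=C/c1ccccc1` gives 190 nM. Compound 4 `CC1=NC(C)=C(C(=O)O)C(c2cccc(Cl)c2)/C1=C(\O)OC/C(C)=C/c1ccccc1` differs from compound 3 in one place only: 1-methyl-2-phenylethenyl in place of 2-cyclohexylethenyl on a saturated chain carbon bound to an oxygen on an unsaturated carbon. Within the data shown here, the single measured step, a 1.5-fold lower number from compound 1 to compound 2 (0.16 log units; within the scatter), changes a different part of the molecule, the group on the saturated ring carbon, and lies within the scatter, so it says nothing about this chain. Among the measured compounds shown here, compounds 1 and 2 also carry a different ring group than compound 3, so no step isolates the chain change. A modest weakening is therefore expected, a 2.7-fold higher number from compound 3 to compound 4 (0.43 log units; beyond the scatter). Compound 4 is estimated at 10 nM, within a range from 2 nM to 50 nM.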

Compound 4, half-maximal inhibitory concentration: 2.8 nM
Beside the measured number, compound 4's estimate is 3.6-fold (0.55 log units) above it, within the range that was stated.
By their numbers in this assay, from the lowest: compounds 4 and 3 (each within the scatter of the next); then compounds 2 and 1 (each within the scatter of the next).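

In this assay the swap to 1-methyl-2-phenylethenyl gives a 1.3-fold lower number from compound 3 to compound 4 (0.12 log units; within the scatter), so at this place, on a saturated chain carbon bound to an oxygen on an unsaturated carbon, the two groups cannot be told apart. The aromatic ring and the added methyl enter together, so this one step cannot separate their contributions. Nothing given here explains the match.

On these data alone, how a chain ending in an amine or a longer chain would fare at this place remains open. So does whether 2-methyl-3-phenylprop-2-en-1-yl would give a similar number alongside the furan-3-yl group of compound 2.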